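Swapping the aryl amine on compound 1

The compounds below may be only part of what the source reports. "The series", "measured", "known", "first", "only" and "open" are said of these compounds alone.

Three ureas on a shared core have been measured in a functional assay on NCI-H520 cells (Homo sapiens) for inhibition, read by MTT assay, with a stated time of 48 h, tested at 10 uM; on this read-out lower numbers stand for less inhibition and higher numbers for more inhibition at the one concentration tested (going by the name of the read-out). Compound 1, with the structure `COc1cc(NC(=O)Nc2cc(Nc3ccc(OC)c(C)c3)ncn2)cc(OC)c1`, gives 13.5% and stands lowest of the three. Compound 2, `COc1cc(Nc2cc(NC(=O)Nc3c(Cl)cccc3Cl)ncn2)cc(OC)c1`, gives 55.5%, and compound 3, `Cc1ccc(Nc2cc(NC(=O)Nc3c(Cl)cccc3Cl)ncn2)cc1C`, gives 47.5%; both lie beyond the scatter above compound 1. Within the data shown here, no pair among the measured compounds differs in only one place, so no single step can be read from them directly.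

Compound 4, `CCc1ccc(Nc2cc(NC(=O)Nc3cc(OC)cc(OC)c3)ncn2)cc1`, keeps the core of compound 1 and its dimethoxyphenyl urea, with the change (4-ethylphenyl in place of 4-methoxy-3-methylphenyl on a nitrogen on an aromatic ring). On these data alone, the measured data contain no comparison in which only the group on that nitrogen is altered, so the size of the step is unknown. Given the low reading of compound 1 in this assay, a modest change in either direction, possibly none beyond the scatter, is the expected outcome, which the estimated step of a number 4.5 percentage points higher from compound 1 to compound 4 (within the scatter) expresses. Compound 4 is therefore expected to give about 18%, with a range from 5% to 35%.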

Compound 4, a percentage reported as inhibition, at one concentration (the size of the read-out at that concentration, not a potency): 23.5%
Beside the measured number, compound 4's estimate is 5.5 percentage points below it, within the range that was stated.
By their numbers in this assay, from the lowest: compounds 1 and 4 (each within the scatter of the next); then compounds 3 and 2 (each within the scatter of the next).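

In this assay, among these compounds, the first comparison that differs in one place, 4-ethylphenyl in place of 4-methoxy-3-methylphenyl on a nitrogen on an aromatic ring, gives a number 10 percentage points higher from compound 1 to compound 4 (within the scatter) while the dimethoxyphenyl urea stays the same. For this pair, then, the change at this position, which removes the ring's only hydrogen-bond acceptor, leaves the two readings within the scatter of each other and does not bring either compound into the range of the two dichlorophenyl ureas. No measurement bears on why the step has this size.

The compounds shown leave open whether a different group on that ring, such as a carboxylic acid or a dimethylamino group, would shift the reading beyond the scatter. They also leave open what a dichlorophenyl urea would do when paired with the 4-ethylphenyl group.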